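Extending the Side Chain on the Aromatic Nitrogen

The source may hold more compounds than are shown below. What is called first, only, known or untested is meant among the compounds shown, and "the series" means these compounds.

Compound 2 `CN1CCC(n2c(CN(C)C3CCCc4cccnc43)nc3ccccc32)CC1` is one of two compounds tested in an ADME assay on HOS cells (Homo sapiens) for cytotoxicity; on this read-out higher numbers stand for lower toxicity in this test and lower numbers for higher toxicity in this test. In this assay compound 2 gives 16000 nM, the upper of the two numbers shown, while compound 1 `CN1CCC(Cn2c(CN(C)C3CCCc4cccnc43)nc3ccccc32)C1` gives 15000 nM, and a 1.1-fold higher number from compound 1 to compound 2 (0.03 log units; within the scatter). Compound 3 `CN1CCCCC1CCn1c(CN(C)C2CCCc3cccnc32)nc2ccccc21` differs from compound 2 by 2-(1-methylpiperidin-2-yl)ethyl in place of 1-methylpiperidin-4-yl on an aromatic nitrogen. Among the measured compounds shown here, the only measured step at this place was within the scatter, so compound 3 is expected to show little movement, a 1.1-fold lower number from compound 2 to compound 3 (0.03 log units; within the scatter) at most. The estimate for compound 3 is therefore 15000 nM, with a range from 7000 nM to 30000 nM.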

Compound 3, half-maximal cytotoxic concentration: 4900 nM
Compound 3: middle estimate off by 3.1-fold (0.49 log units), on the high side, and the stated range ends above it.
By their numbers in this assay, from the lowest: compound 3; then compounds 1 and 2 (each within the scatter of the next).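

In this assay, the side chain on the aromatic nitrogen proves able to move the number: 2-(1-methylpiperidin-2-yl)ethyl gives a 3.3-fold lower number from compound 2 to compound 3 (0.51 log units; beyond the scatter) and so lies beyond the scatter, unlike the earlier change here. The comparison with the other earlier side chain agrees, with a 3.1-fold lower number from compound 1 to compound 3 (0.49 log units; beyond the scatter) as its step. Nothing available explains this fall. The compounds shown leave open whether the ethyl chain or the point of attachment on the piperidine ring carries the change, and how a side chain ending in a morpholine or a carboxylic acid would read.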